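The compounds below may be only part of what the source reports. "The series", "measured", "known", "first", "only" and "open" are said of these compounds alone.

In an assay on isolated protein for inhibition of leukotriene B4 receptor 1 (Homo sapiens), tested at 10 uM (a lower number here means less inhibition, a higher number more inhibition at the concentration tested (going by the name of the read-out)), compound 3 `C=CCc1cc(C(C)=O)c(O)cc1OCCCCC#N` gives 92%, the highest of the three measured numbers. Compound 1 `CCCCCc1cc(C(C)=O)c(O)cc1OCCCCC#N` gives 31%, and compound 2 `CC(=O)c1cc(CC(C)O)c(OCCCCC#N)cc1O` gives 10%. Every measured step alters the chain bound to the aromatic carbon: a number 61 percentage points higher from compound 1 to compound 3 (beyond the scatter), a number 82 percentage points higher from compound 2 to compound 3 (beyond the scatter) and a number 21 percentage points lower from compound 1 to compound 2 (beyond the scatter). Compound 4 `C=CCc1cc(C(C)=O)c(O)cc1OCCCCO` instead alters a different part of the molecule: hydroxy in place of cyano on a saturated chain carbon, four bonds along the chain from an oxygen on an aromatic ring. Within the data shown here, no measured step touches this part, so there is no direct guide; the measured steps show only that this assay can shift strongly with small changes elsewhere. A modest loss with wide uncertainty is therefore expected, and a number 22 percentage points lower from compound 3 to compound 4 (beyond the scatter) is the estimated step. Compound 4 is expected to give 70%, within 35% to 95%.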

Compound 4, a percentage reported as inhibition, at one concentration (the size of the read-out at that concentration, not a potency): 48%
Beside the measured number, compound 4's estimate is 22 percentage points above it, within the range that was stated.
By their numbers in this assay, from the lowest: compound 2; then compound 1; then compound 4; then compound 3.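

This position, at the far end of the chain, matters too: hydroxy in place of cyano gives a number 44 percentage points lower from compound 3 to compound 4 (beyond the scatter) in this assay, so changes to the chain bound to the aromatic carbon are not the only ones that move this number. Compound 4 still gives 48%, so inhibition does not vanish when the nitrile is replaced. No measurement here explains this loss. Going by these compounds, whether an amine or a carboxylic acid at this chain end would give a number closer to that of compound 3 stays open, as does the effect of a longer chain ending in a nitrile.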